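Swapping the chlorinated ring on a shared diaminotriazine core

The source may report more compounds than this note shows. Statements on the series, on what has been measured and on what is new or still open speak of the compounds shown alone.

Four compounds share one core: a spiro-fused, doubly aminated six-membered ring carrying an oxygen-linked three-carbon chain that ends in an aryl ether. Compound 1 `COc1ccc(OCCCON2C(N)=NC(N)=NC23CCOCC3)cc1` bears a saturated ring with an oxygen and a 4-methoxyphenyl ether. In an assay on isolated protein for inhibition of Dihydrofolate reductase (Homo sapiens), read by spectrophotometry, using NADPH, with stated times of 5 s and 6 min (a higher number here means a weaker inhibitor, a lower number a stronger inhibitor), compound 1 gives 11.1 nM. Compound 2 `NC1=NC2(CCOCC2)N(OCCCOc2cccc(Cl)c2Cl)C(N)=N1` keeps the oxygen-containing saturated ring but carries a 2,3-dichlorophenyl ether; in this assay compound 2 is recorded as "not determined" (no result reported), so no result has been reported for it. Compound 3 `NC1=NC2(CCSCC2)N(OCCCOc2cccc(Cl)c2Cl)C(N)=N1` replaces the oxygen of that saturated ring with sulfur and keeps the 2,3-dichlorophenyl ether; in this assay compound 3, too, is recorded as "not determined" (no result reported), so no number has been reported for it, compound 3 stands nowhere on the numbers at hand, and nothing can be said of how it compares with compound 1.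

Compound 4 `NC1=NC2(CCSCC2)N(OCCCOc2ccc(Cl)cc2)C(N)=N1` is not yet measured. It differs from compound 3 in one place: 4-chlorophenyl in place of 2,3-dichlorophenyl on an oxygen on a saturated carbon. Among the compounds with values here, no step between measured compounds describes this change, so its size and direction cannot be read from the data; the only anchor is that a compound with this core and an unrelated aryl ether, compound 1, is a strong inhibitor. Compound 4 is expected to land near that anchor, estimated at 12 nM with a range from 3 nM to 60 nM, because compound 1 gives 11.1 nM in this assay.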

Compound 4, half-maximal inhibitory concentration: 18.3 nM
Compound 4: the middle estimate sits 1.5-fold (0.18 log units) below what was measured; the measured number falls inside the stated range.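

No step can be read from compound 3 to compound 4: in this assay compound 3 has no single number to set against compound 4 at 18.3 nM. The compounds shown leave open whether 4-chlorophenyl in place of 2,3-dichlorophenyl shifts inhibition at all, and in which direction. Nothing at hand offers an explanation for this result.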